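Replacing (4-chlorophenyl)carbonyl with phenyl on a shared core

This account rests on a few compounds, and the source may have more. Where it says the series, first, only, none or still open, it means among the compounds named here.

Measured so far in a physicochemical assay for metabolic stability, read by HPLC, in phosphate buffer, at pH 7.4, tested at 10 uM; a lower number here means that the compound disappears faster, a higher number that the compound lasts longer
Compound 1 `O=C(c1ccccc1)c1ccc2c(c1)oc(=O)n2C(=O)NCCCCc1ccccc1` gives 1.63 h
Compound 2 `O=C(c1ccc(Cl)cc1)c1ccc2c(c1)oc(=O)n2C(=O)NCCCCc1ccccc1` gives 4.57 h

Compound 2 stands with 4.57 h as the higher of the two numbers, and its gap to compound 1 lies beyond the scatter. Compound 3 `O=C(NCCCCc1ccccc1)n1c(=O)oc2cc(-c3ccccc3)ccc21` is still unmeasured. It differs from compound 2 by phenyl in place of (4-chlorophenyl)carbonyl on an aromatic carbon in a single change, phenyl in place of (4-chlorophenyl)carbonyl on an aromatic carbon. Among the compounds with values here, only one measured step bears on this, the modest 2.8-fold higher number from compound 1 to compound 2 (0.45 log units; beyond the scatter) on adding chloro. Compound 3 also lacks that chloro, which hints at a modest fall, but no measurement shows what losing the carbonyl does. No clear move beyond the scatter is therefore expected in this assay, and the estimated step is a 1.1-fold lower number from compound 2 to compound 3 (0.06 log units; within the scatter) in size. Compound 3 is expected to show 4 h as its half-life, with an estimated range from 1.3 h to 14 h.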

Compound 3, half-life: > 5 h
Compound 3 gave a limit, no number; the forecaster's own chance of this, stated with the estimate: 3%; middle value at least 1.2-fold (0.09 log units) away from the limit.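

In this assay compound 3 gives > 5 h, which is a limit and not a number. Phenyl in place of benzoyl on this aromatic carbon gives an at least 3.0-fold higher number from compound 1 to compound 3 (0.48 log units; beyond the scatter), so the half-life at this position does not depend on keeping the carbonyl, a point the chloro step alone could not show. Against the chlorinated compound the reading is only a floor, an at least 1.0-fold higher number from compound 2 to compound 3 (0.03 log units; that floor lies within the scatter), so the data cannot tell whether phenyl or (4-chlorophenyl)carbonyl lasts longer here: the limit of > 5 h in this assay, at which 1 of the 3 values shown sits.

Going by these compounds, how far the half-life of compound 3 extends past that limit remains open. Also open, on these data alone, is how a chloro on the phenyl of compound 3, or an amine or a carboxylic acid on this aromatic carbon, would read in this assay.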